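Replacing Ethoxy with 4-Carboxyphenyl on a Shared Core

A few compounds are considered here, and "the series" means these few. Any claim that something is new, unique, unknown or untested is made for them only; others in the source may bear on it.

Of the compounds shown here, three sharing one core have been tested in a functional assay on T47D cells (Homo sapiens) for antiproliferative activity, with a stated time of 72 h; on this read-out higher numbers stand for weaker inhibition and lower numbers for stronger inhibition. Compound 1 `CSc1cnc2ccccc2c1SCC#CCOC(=O)/C=C/c1ccccc1` gives 71.9 ug/mL, compound 2 `CSc1cnc2ccccc2c1[Se]CC#CCCl` gives 0.7 ug/mL, and compound 3 `CCOC(=O)OCC#CCSc1c(SC)cnc2ccccc12` gives 34.2 ug/mL. Compound 3 thus stands second highest of the three, far nearer to compound 1 than to compound 2. Compound 4 `CSc1cnc2ccccc2c1SCC#CCOC(=O)c1ccc(C(=O)O)cc1` differs from compound 3 by 4-carboxyphenyl in place of ethoxy on a carbonyl carbon. Among the measured compounds shown here, only one measured step alters this same carbonyl carbon, namely a 2.1-fold lower number from compound 1 to compound 3 (0.32 log units; beyond the scatter). Because a 2.1-fold lower number from compound 1 to compound 3 (0.32 log units; beyond the scatter) was only modest, and the change in compound 4 again touches that carbonyl carbon, a modest step is expected, probably toward the number of compound 1. The expected step is a 1.8-fold higher number from compound 3 to compound 4 (0.24 log units; within the scatter). Compound 4 is therefore estimated at 60 ug/mL, with a range from 20 ug/mL to 150 ug/mL.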

Compound 4, concentration for 50% inhibition: 36.1 ug/mL
Compound 4: middle estimate off by 1.7-fold (0.22 log units), on the high side; the range from low to high includes it.
By their numbers in this assay, from the lowest: compound 2; then compounds 3, 4 and 1 (each within the scatter of the next, the first and the last beyond it).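

In this assay, putting 4-carboxyphenyl, with its six-membered aromatic ring and hydrogen-bond donor, in place of ethoxy on this carbonyl carbon gives a 1.1-fold higher number from compound 3 to compound 4 (0.02 log units; within the scatter), so this large change leaves no measurable difference. Putting the same group in place of 2-phenylethenyl gives a 2.0-fold lower number from compound 1 to compound 4 (0.30 log units; within the scatter), which means that, among the three groups at this carbonyl carbon, only compound 1 and compound 3 differ beyond the scatter. Nothing shown here explains this result. The compounds shown leave open whether a plain phenyl or an amine on this carbonyl carbon would move the number, and whether the carboxylic acid of compound 4 contributes anything.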